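Swapping the bicyclic amine on the urea of compound 1

The source may hold more compounds than are shown below. What is called first, only, known or untested is meant among the compounds shown, and "the series" means these compounds.

Measured so far:
- compound 1, `Cn1ccc2nccc(NC(=O)NCCN3CCC(O)(Cc4ccccc4)CC3)c21`: 600 nM in an assay on HEK293 cells for displacement of a labelled ligand from Urotensin-2 receptor (Homo sapiens); on this read-out lower numbers stand for stronger inhibition and higher numbers for weaker inhibition
- compound 2, `O=C(NCCN1CCC(O)(Cc2cccc(Br)c2)CC1)Nc1ccnc2ccsc12`: 42 nM in this assay

Compound 1 has the highest of the two numbers in this assay; compound 2 sits well below it, at a distance beyond the scatter of repeated measurements. Among the compounds with values here, the two compounds differ in more than one place, so the gap between them cannot be tied to a single change, and no single step between them is given.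

Compound 3, `O=C(NCCN1CCC(O)(Cc2ccccc2)CC1)Nc1ccnc2sccc12`, is the next compound to be measured in this assay. It differs from compound 1 in one place: a group of 9 heavy atoms (7 carbon, 1 nitrogen, 1 sulfur; one five-membered aromatic ring with 1 hetero atom, one six-membered aromatic ring with 1 hetero atom) in place of a group of 10 heavy atoms (8 carbon, 2 nitrogen; one five-membered aromatic ring with 1 hetero atom, one six-membered aromatic ring with 1 hetero atom), on an amide-type nitrogen. The rest of the molecule, the urea linker, the hydroxypiperidine and the benzyl group, is unchanged.

Within the data shown here, with no measured pair that isolates this exchange, the expectation rests on compound 2, which carries a closely related bicyclic amine and gives 42 nM in this assay. On that basis compound 3 is expected to give a lower number than compound 1, a step of a 3.0-fold lower number from compound 1 to compound 3 (0.48 log units; beyond the scatter), though the uncertainty is wide. The estimate for compound 3 in this assay is 200 nM, with a plausible range from 60 nM to 700 nM.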

Compound 3, half-maximal inhibitory concentration: 930 nM
For compound 3 the middle estimate is 4.7-fold (0.67 log units) below the measured one; measured number outside the range, above it.
By their numbers in this assay, from the lowest: compound 2; then compounds 1 and 3 (each within the scatter of the next).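

Within the data shown here, compound 3 gives the first direct reading at this position: with the urea linker, the hydroxypiperidine and the benzyl group held constant, exchanging one two-ring group for the other on the amide-type nitrogen gives a 1.6-fold higher number from compound 1 to compound 3 (0.19 log units; within the scatter) in this assay. That step lies within the scatter of repeated measurements, so this read-out does not tell the two compounds apart, even though the entering group carries a sulfur atom and the leaving group carries a second nitrogen. Nothing measured here explains why the exchange leaves the two numbers indistinguishable.

The compounds shown contain no pair that isolates the bromine on the benzyl group of compound 2, so its contribution on its own stays unknown, as does the contribution of the two-ring group that compound 2 carries on the urea. Also open, from the compounds shown here alone, is what a chlorine atom or a methoxy group on the benzyl group would do, or a plain phenyl ring on the amide-type nitrogen in place of either two-ring group of compound 1 and compound 3.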